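A few compounds are considered here, and "the series" means these few. Any claim that something is new, unique, unknown or untested is made for them only; others in the source may bear on it.

Compound 1 `CCC1C(=O)N(C)c2cnc(-n3ccnc3-c3ccc(F)cc3)nc2N1c1ccc(F)cc1`: 47%
Compound 2 `CCC1C(=O)N(C)c2cnc(-n3ccnc3-c3ccc(F)cc3)nc2N1C1CCC(F)(F)C1`: 6%

In an ADME assay on microsomes from liver (Homo sapiens) for metabolic stability, with a stated time of 30 min, tested at 1 uM (a higher number here means that more of the compound is left, a lower number that less of the compound is left), compound 2, at 6% remaining, is the lower of the two measured compounds. Compound 3 `CCC1C(=O)N(C)c2cnc(-n3ccnc3-c3ccc(F)cc3)nc2N1c1ccc(C#N)cc1` carries 4-cyanophenyl in place of 3,3-difluorocyclopentyl on a nitrogen on an aromatic ring in a ring. Within the data shown here, one measured step bears on this: the large drop a number 41 percentage points lower from compound 1 to compound 2 (beyond the scatter) beyond the scatter, where 3,3-difluorocyclopentyl took the place of 4-fluorophenyl at the same nitrogen. Among the measured compounds shown here, compound 3 again has a phenyl ring there, as does compound 1 (47%), but with a nitrile instead of fluorine, and no measured pair isolates that swap. A large rise is therefore expected in this assay (a number 39 percentage points higher from compound 2 to compound 3 (beyond the scatter)), roughly reversing that drop. For compound 3 the expected value is 45% with an estimated range from 25% to 65% in this read-out.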

Compound 3, percent of the compound remaining in the Homo sapiens assay: 63%
Estimate against measurement, compound 3: 18 percentage points below, and the stated range covers the measured number.
By their numbers in the Homo sapiens assay, from the lowest: compound 2; then compound 1; then compound 3.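

Compound 3 shows that restoring an aromatic ring on this nitrogen does more than recover the level of compound 1. In the Homo sapiens assay, the swap of 3,3-difluorocyclopentyl for 4-cyanophenyl gives a number 57 percentage points higher from compound 2 to compound 3 (beyond the scatter), and the change on the phenyl ring alone, with the ring itself kept, gives a number 16 percentage points higher from compound 1 to compound 3 (beyond the scatter), so the group carried by that ring also counts at this position. The same swap at the nitrogen yields a more polar compound in a physicochemical assay for lipophilicity; a lower number here means a more polar compound, a higher number a more lipophilic compound: the measured partition coefficient of compound 2, 3.1, and of compound 3, 2.7, a number 0.40 log units lower (beyond the scatter) In the physicochemical assay compound 2 gives 3.1 and compound 3 gives 2.7.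

The compounds shown leave open whether the number in the microsomal read-out follows the partition coefficient beyond this one pair. They also leave open how a methoxy group or an amide on the phenyl ring, or a morpholine ring on this nitrogen, would compare.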